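The compounds below may be only part of what the source reports. "The series", "measured", "known", "first", "only" and "open" are said of these compounds alone.

Compound 1 `COc1ccc(S(=O)(=O)N2CCc3cccc(-c4ccc(C#N)cc4)c32)cc1` stands strongest of the three measured compounds in a functional assay on HT-29 cells (Homo sapiens) for inhibition, with a stated time of 72 h (a higher number here means a weaker inhibitor, a lower number a stronger inhibitor), giving 24.2 nM. Compound 3 `COc1ccc(S(=O)(=O)n2ccc3cccc(-c4ccc(C#N)cc4)c32)cc1` gives 164 nM, and compound 2 `COc1ccc(-c2cccc3c2N(S(=O)(=O)c2ccc(OC)cc2)CC3)cc1` gives 277 nM. Going by the values given here, the one single-change step among them, an 11-fold higher number from compound 1 to compound 2 (1.06 log units; beyond the scatter), shows that losing the cyano group costs a great deal of potency. Compound 4 `COc1ccc(S(=O)(=O)N2CCc3cccc(-c4ccco4)c32)cc1` differs from compound 1 by furan-2-yl in place of 4-cyanophenyl on an aromatic carbon. Among the compounds with values here, this change also removes the cyano group, and further swaps the whole six-membered ring for a smaller five-membered one, so no measured step matches it exactly. A clearly weaker compound is expected, though the size is uncertain because the step of an 11-fold higher number from compound 1 to compound 2 (1.06 log units; beyond the scatter) is only a partial guide. For compound 4 the estimate is 180 nM, within 45 nM to 700 nM, an expected step of a 7.4-fold higher number from compound 1 to compound 4 (0.87 log units; beyond the scatter).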

Compound 4, half-maximal inhibitory concentration: 62.5 nM
Compound 4: the middle estimate sits 2.9-fold (0.46 log units) above what was measured; the measured number falls inside the stated range.
By their numbers in this assay, from the lowest: compound 1; then compound 4; then compounds 3 and 2 (each within the scatter of the next).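

Swapping 4-cyanophenyl for furan-2-yl at this aromatic carbon gives a 2.6-fold higher number from compound 1 to compound 4 (0.41 log units; beyond the scatter), so a smaller five-membered ring with no nitrile still costs only a modest amount of potency. The same ring gives a 4.4-fold lower number from compound 2 to compound 4 (0.65 log units; beyond the scatter), so the nitrile is not the only feature that matters here, and 4-methoxyphenyl is not the best nitrile-free group at this carbon.

Nothing measured here explains why furan-2-yl outperforms 4-methoxyphenyl. Also open, going by these compounds, is how a pyridine ring or a phenyl ring bearing a carboxylic acid would fare at this carbon.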